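The source may hold more compounds than are shown below. What is called first, only, known or untested is meant among the compounds shown, and "the series" means these compounds.

Measured so far in a functional assay on HOP-62 cells (Homo sapiens) for inhibition, read by sulforhodamine B assay, with a stated time of 48 h (on this read-out lower numbers stand for stronger inhibition of growth and higher numbers for weaker inhibition of growth), are three compounds that share one core:

Compound 1 `O=C(Cc1csc2nc(-c3ccc(Br)cc3)cn12)N/N=C/c1ccccc1` gives 39800 nM
Compound 2 `O=C(Cc1csc2nc(-c3ccc(Br)cc3)cn12)N/N=C/c1ccccc1O` gives 14800 nM
Compound 3 `COc1cccc(OC)c1/C=N/NC(=O)Cc1csc2nc(-c3ccc(Br)cc3)cn12` gives 30200 nM

Compound 3 lies within the usual scatter of compound 1 (a 1.3-fold lower number from compound 1 to compound 3 (0.12 log units; within the scatter)). Its number is clearly higher than that of the hydroxy compound, meaning weaker inhibition of growth (a 2.0-fold higher number from compound 2 to compound 3 (0.31 log units; beyond the scatter)).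

The next compound, compound 4 `O=C(Cc1csc2nc(-c3ccc(Br)cc3)cn12)N/N=C/c1ccc(Cl)cc1Cl`, has not yet been measured. It differs from compound 3 by 2,4-dichlorophenyl in place of 2,6-dimethoxyphenyl on a carbon with a double bond to nitrogen and so carries 2,4-dichlorophenyl in place of 2,6-dimethoxyphenyl on a carbon with a double bond to nitrogen.

Among the compounds with values here, no measured compound carries chlorine, so the evidence is indirect. At this same place, exchanging phenyl for 2,6-dimethoxyphenyl gave a 1.3-fold lower number from compound 1 to compound 3 (0.12 log units; within the scatter) and no shift beyond the scatter. Adding a hydroxy gave the one modest move, a 2.7-fold lower number from compound 1 to compound 2 (0.43 log units; beyond the scatter) and the 2,4-dichlorophenyl group has no hydroxy. A step beyond the scatter is therefore not expected in this assay and its direction is uncertain. The estimated step is a 1.1-fold lower number from compound 3 to compound 4 (0.05 log units; within the scatter) and it is expected to be small. For compound 4 the estimate is 27000 nM with an expected range from 12000 nM to 62000 nM for four of five measurements.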

Compound 4, concentration for total growth inhibition: 34700 nM
Estimate against measurement, compound 4: 1.3-fold (0.11 log units) below; measured number inside the range.
By their numbers in this assay, from the lowest: compound 2; then compounds 3, 4 and 1 (each within the scatter of the next).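

In this assay, the first chlorine-bearing ring at this position cannot be told apart from the 2,6-dimethoxyphenyl ring (a 1.1-fold higher number from compound 3 to compound 4 (0.06 log units; within the scatter)) or from plain phenyl (a 1.1-fold lower number from compound 1 to compound 4 (0.06 log units; within the scatter)), so placing two chlorine atoms on the ring or two methoxy groups on it gives the same result within the scatter. The hydroxy compound remains the only one of the four that stands apart, and compound 4 shows weaker inhibition of growth than it does (a 2.3-fold higher number from compound 2 to compound 4 (0.37 log units; beyond the scatter)), so among these compounds only the 2-hydroxyphenyl ring separates from the others, and none goes against this. Nothing available here explains why the 2-hydroxyphenyl ring alone stands apart.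

The compounds shown leave open whether other groups on this ring, such as an amine or a carboxylic acid, would also separate from plain phenyl, and whether a hydroxy would do so at another place on the ring. Going by these compounds, all four compounds also keep the shared core unchanged, so it remains unknown whether these small and modest steps would hold on a different core.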